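The source may hold more compounds than are shown below. What is called first, only, known or untested is meant among the compounds shown, and "the series" means these compounds.

Measured in a physicochemical assay for solubility, using the shake flask method, measured as kinetic solubility, with a stated time of 20 h, at pH 2; on this read-out higher numbers stand for higher solubility and lower numbers for lower solubility:

Compound 1 `FC(F)(F)Oc1ccc(-c2nc3cnc(Nc4ccccn4)cc3[nH]2)cc1`: 26000 nM
Compound 2 `COc1ccc(Nc2cc3[nH]c(-c4cccc(C(F)(F)F)c4)nc3cn2)nc1`: < 5000 nM
Compound 3 `Fc1ccc(-c2nc3cnc(Nc4ccccn4)cc3[nH]2)cc1C(F)(F)F`: 7000 nM

Going by the values given here, only two of these three compounds return a number. Compound 2 stands at < 5000 nM, and this is a limit of the assay, not a number. Among the compounds with values here, its true position in this assay is therefore not known, and the same limit is the only anchor for the step that follows.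

Compound 4 `FC(F)(F)c1ccc(Nc2cc3[nH]c(-c4cccc(C(F)(F)F)c4)nc3cn2)nc1` is the unmeasured partner of compound 2. It carries trifluoromethyl in place of methoxy on an aromatic carbon, two atoms from the ring nitrogen and para to a large group, so that 5-methoxypyridin-2-yl becomes 5-(trifluoromethyl)pyridin-2-yl (trifluoromethyl in place of methoxy on an aromatic carbon). The rest of the structure stays the same.

Within the data shown here, no pair of measured compounds differs in one place, so the data offer no direct precedent for this change. In this assay, no step beyond the usual scatter is expected, with only a slight lean towards lower numbers. A report of a limit alone is more likely than a number for this compound. The estimated change is a step that the limit leaves unreadable from compound 2 to compound 4. For compound 4 the expected value is 3000 nM, with an estimated range from 800 nM to 8000 nM.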

Compound 4, solubility: < 5000 nM
Compound 4: no number, only a limit; the forecaster's own chance of this, stated with the estimate: 65%; the middle value does not contradict the limit.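

In this assay compound 4 gives < 5000 nM, which is a limit of the assay and not a number. No step can be read between compound 2 and compound 4, because both rest on the same limit: the limit of < 5000 nM in this assay, at which 2 of the 4 values shown sit. The compounds shown leave open where compound 2 and compound 4 truly lie, and whether trifluoromethyl in place of methoxy changes the read-out at all.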